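Terminal amine capping on the compound 2 side chain

The source may hold more compounds than are shown below. What is called first, only, known or untested is meant among the compounds shown, and "the series" means these compounds.

Compound 1 `CC(C)(C)OC(=O)NC1CCCN(C(=O)CN2CN(c3ccccc3)C3(CCN(C(=O)c4ccc(C(C)(C)C)cc4)CC3)C2=O)C1`: 4200 nM
Compound 2 `CC(C)(C)c1ccc(C(=O)N2CCC3(CC2)C(=O)N(CC(=O)NCCCN)CN3c2ccccc2)cc1`: 4200 nM

Both values come from an assay on HEK293 cells for displacement of a labelled ligand from NPC1-like intracellular cholesterol transporter 1 (Homo sapiens); on this read-out lower numbers stand for stronger inhibition and higher numbers for weaker inhibition. Compound 2 stands level with compound 1 at the digits shown; the two differ in more than one place, so only what the two values show can be said: they sit together, with no change beyond the scatter between them.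

Compound 3 `CC(C)(C)c1ccc(C(=O)N2CCC3(CC2)C(=O)N(CC(=O)NCCCNS(C)(=O)=O)CN3c2ccccc2)cc1` has not yet been measured in this assay. It differs from compound 2 in one place: methylsulfonyl in place of hydrogen on an amine nitrogen. Cut one bond further out, the change reads amino to methanesulfonamido on the chain that ends the side chain of compound 2.

Going by the values given here, no measured pair in this set carries this change, so nothing here says which way it moves the read-out. Among the compounds with values here, the only guide is that compound 1 and compound 2 sit together despite differing on the same side of the molecule. On that basis the step is expected to be small, within the scatter or close to it, estimated as a 1.1-fold lower number from compound 2 to compound 3 (0.02 log units; within the scatter). Compound 3 is therefore expected to come out near 4000 nM, with a range from 1500 nM to 12000 nM in this assay.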

Compound 3, half-maximal inhibitory concentration: 10400 nM
For compound 3 the middle estimate is 2.6-fold (0.41 log units) below the measured one; the range from low to high includes it.
By their numbers in this assay, from the lowest: compounds 1 and 2 (each within the scatter of the next); then compound 3.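

In this assay the methylsulfonyl group in place of hydrogen on the amine nitrogen gives a 2.5-fold higher number from compound 2 to compound 3 (0.39 log units; beyond the scatter) and so moves the number upward, towards weaker inhibition. Going by these compounds alone, this is the first one-place comparison, and it shows that the amine nitrogen of the compound 2 side chain is a position where a substitution can register beyond the scatter, though only modestly. No measurement in hand bears on the reason for this rise.

On these data alone, whether the rise belongs to methylsulfonyl itself or would follow any group placed on this nitrogen remains open, and an acetyl amide, a methyl carbamate or a simple dimethylamine on the same chain would help separate those readings. Also open, as far as these compounds go, is how far the position tolerates wider change, such as a longer chain carrying the same amine or a carboxylic acid in place of the amine.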